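The compounds below may be only part of what the source reports. "The series", "measured", "known", "first", "only" and "open" are said of these compounds alone.

Measured compounds in a functional assay on EC9706 cells (Homo sapiens) for cytotoxicity, read by MTT assay, with a stated time of 72 h; a lower number here means a stronger inhibitor, a higher number a weaker inhibitor:
compound 1, `O=C(CSC(=S)N[C@H]1CCOC1=O)Nc1ccccc1`, > 128000 nM
compound 2, `O=C(CSC(=S)N[C@H]1CCOC1=O)Nc1cccc(C(F)(F)F)c1`, 79700 nM
compound 3, `O=C(CSC(=S)N[C@H]1CCOC1=O)Nc1cccc([N+](=O)[O-])c1`, > 128000 nM

Compound 1 stands at a limit of the assay, not at a number: the limit of > 128000 nM in this assay, at which 2 of the 3 values shown sit. Compound 3 likewise returns only a limit. Compound 2 alone carries a number, so the step of an at least 1.6-fold lower number from compound 1 to compound 2 (0.20 log units; that floor lies within the scatter) reads only as a floor, the step that the two limits leave unreadable from compound 1 to compound 3 cannot be read, and the step of an at least 1.6-fold higher number from compound 2 to compound 3 (0.20 log units; that floor lies within the scatter) is again only a floor. Compound 4, `O=C(CSC(=S)N[C@H]1CCOC1=O)Nc1ccc(C(=O)/C=C/c2ccccc2)cc1`, is made from compound 1 by (2-phenylethenyl)carbonyl in place of hydrogen on an aromatic carbon. Within the data shown here, the two measured steps from compound 1 both replace a hydrogen on an aromatic carbon of the same ring, and neither gave a step readable beyond the scatter; a group of the size entering in compound 4 has no counterpart among the measured compounds. For compound 4 a weak number near the limit is therefore expected, 40000 nM, within 10000 nM to 128000 nM, which means an expected at least 3.2-fold lower number from compound 1 to compound 4 (0.50 log units; beyond the scatter).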

Compound 4, half-maximal inhibitory concentration: 44900 nM
Compound 4: the middle estimate sits 1.1-fold (0.05 log units) below what was measured; the range from low to high includes it.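

Placing (2-phenylethenyl)carbonyl on this ring carbon, para to a large group, gives in this assay an at least 2.8-fold lower number from compound 1 to compound 4 (0.45 log units; beyond the scatter). Among these compounds, this is the first step from compound 1 that reads beyond the scatter, as the earlier replacements on the ring gave only a floor within the scatter or a step that cannot be read. The ring carbon therefore accepts a group of 10 heavy atoms with a further aromatic ring while the number falls, but the size of the step is only a floor, since compound 1 returns a limit: the limit of > 128000 nM in this assay, at which 2 of the 4 values shown sit.

The compounds shown do not separate the part played by the carbonyl, the double bond and the outer phenyl ring, and a saturated chain in place of the double bond would bear on this. As far as these compounds go, how a small group such as an amine or a carboxylic acid would read at this same place also remains open.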